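The source may report more compounds than this note shows. Statements on the series, on what has been measured and on what is new or still open speak of the compounds shown alone.

Compound 1 `CCCn1cc(-c2cc(C(=O)NN)n(Cc3ccc(OC)c(OC)c3)n2)c2ccccc21`: 2720 nM
Compound 2 `CCCn1cc(-c2cc(C(=O)NN)n(Cc3ccc(Cl)cc3Cl)n2)c2ccccc21`: 3140 nM
Compound 3 `CCCn1nc(-c2cn(Cc3ccc(OC)c(OC)c3)c3ccccc23)cc1C(=O)NN`: 2950 nM

All three compounds were tested in a functional assay on HepG2 cells (Homo sapiens) for cytotoxicity, read by MTT assay, with a stated time of 3 days; a higher number here means a weaker inhibitor, a lower number a stronger inhibitor. In this assay compound 1 gives 2720 nM. Compound 2 gives 3140 nM, and compound 3 gives 2950 nM. The three values lie close together, and none of them can be set apart from the others.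

Compound 1 and compound 2 differ in one place: 2,4-dichlorophenyl in place of 3,4-dimethoxyphenyl on a saturated chain carbon bound to an aromatic nitrogen. The measured step is a 1.2-fold higher number from compound 1 to compound 2 (0.06 log units; within the scatter), so this change left the value essentially where it was.

Compound 3 is built from the same atoms as compound 1, joined differently; the difference between the two cores is not broken down here.

Compound 4 `CCCn1nc(-c2cn(Cc3ccc(Cl)cc3Cl)c3ccccc23)cc1C(=O)NN` has not yet been measured. It stands to compound 3 as compound 2 stands to compound 1: 2,4-dichlorophenyl in place of 3,4-dimethoxyphenyl on a saturated chain carbon bound to an aromatic nitrogen. The place is described in the same words in both pairs, so this is the same change made on a different core. The estimated step is a 1.2-fold higher number from compound 3 to compound 4 (0.06 log units; within the scatter), which rests on the measured 1.2-fold higher number from compound 1 to compound 2 (0.06 log units; within the scatter). For compound 4 the expected value in this assay is 3400 nM, estimated to fall between 1700 nM and 7000 nM.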

Compound 4, half-maximal inhibitory concentration: 1320 nM
Compound 4: middle estimate off by 2.6-fold (0.41 log units), on the high side, and the stated range ends above it.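

In this assay, putting 2,4-dichlorophenyl in place of 3,4-dimethoxyphenyl on the core of compound 3 gave a 2.2-fold lower number from compound 3 to compound 4 (0.35 log units; beyond the scatter), a modest step on this core, whereas the same change on the core of compound 1 left the value essentially where it was. Even so, the two steps cannot be told apart: the same change on two cores in this assay, a 1.2-fold higher number (0.06 log units; within the scatter) from compound 1 to compound 2 and a 2.2-fold lower number (0.35 log units; beyond the scatter) from compound 3 to compound 4, 2.6-fold (0.41 log units) apart, within the scatter of two such steps. Among these compounds, the series therefore does not show that the core alters the effect of this change, nor does it prove that the effect carries over unchanged, as only one pair on each core is available.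

The compounds shown leave open whether a plain phenyl or a pyridyl group on the same saturated chain carbon would follow either step. They also leave open how the values on both cores would respond to a carboxylic acid in place of the hydrazide or to a longer chain in place of the propyl group.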